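Moving a hydroxymethyl group on a piperidine benzyl arm

This account rests on a few compounds, and the source may have more. Where it says the series, first, only, none or still open, it means among the compounds named here.

Measured so far:
compound 1, `Cc1c(C)c2ccc(OCC3CCCN(Cc4ccc(CO)cc4)C3)cc2oc1=O`, 76 nM;
compound 2, `Cc1c(C)c2ccc(OCC3CCCN(Cc4cccc(CO)c4)C3)cc2oc1=O`, 110 nM;
compound 3, `Cc1c(C)c2ccc(OCC3CCN(Cc4ccc(CO)cc4)CC3)cc2oc1=O`, 29 nM.

All three were tested in an assay for inhibition of Amine oxidase [flavin-containing] B (Homo sapiens), read by fluorescence, using microsomes, with a stated time of 30 min; on this read-out lower numbers stand for stronger inhibition and higher numbers for weaker inhibition. Compound 1 gives 76 nM and compound 2 gives 110 nM; the change between them is 3-(hydroxymethyl)phenyl in place of 4-(hydroxymethyl)phenyl on a saturated chain carbon bound to an amine nitrogen in a ring and the step is a 1.4-fold higher number from compound 1 to compound 2 (0.16 log units; within the scatter). Compound 3 gives the lowest number, 29 nM, and its gaps to compound 1 and compound 2 both lie beyond the scatter; the difference between its core and that of compound 1 is not broken down here. Compound 4, `Cc1c(C)c2ccc(OCC3CCN(Cc4cccc(CO)c4)CC3)cc2oc1=O`, is not yet measured; it differs from compound 3 by 3-(hydroxymethyl)phenyl in place of 4-(hydroxymethyl)phenyl on a saturated chain carbon bound to an amine nitrogen in a ring, the same change made from compound 1 to compound 2. Because that earlier step was a 1.4-fold higher number from compound 1 to compound 2 (0.16 log units; within the scatter), a step of similar size is expected here, a 1.4-fold higher number from compound 3 to compound 4 (0.14 log units; within the scatter). Compound 4 is therefore estimated at 40 nM, within 20 nM to 85 nM.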

Compound 4, half-maximal inhibitory concentration: 76 nM
Beside the measured number, compound 4's estimate is 1.9-fold (0.28 log units) below it; the measured number falls inside the stated range.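

In this assay, 3-(hydroxymethyl)phenyl in place of 4-(hydroxymethyl)phenyl gives a 2.6-fold higher number from compound 3 to compound 4 (0.42 log units; beyond the scatter). Set beside the same change on the core of compound 1, the two steps cannot be told apart: the same change on two cores in this assay, a 1.4-fold higher number (0.16 log units; within the scatter) from compound 1 to compound 2 and a 2.6-fold higher number (0.42 log units; beyond the scatter) from compound 3 to compound 4, 1.8-fold (0.26 log units) apart, within the scatter of two such steps. Among these compounds, this shows that, on these two cores, the size of the step carries over within the scatter, but two pairs do not make a rule for other cores, and only the step on the core of compound 3 stands clear of the scatter.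

The compounds shown leave open how an amine, a carboxylic acid or a methoxy group would compare with the hydroxymethyl group on the benzyl arm. They also leave open whether a longer chain bearing the hydroxyl would follow the same trend.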